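Chloro on compound 1: working notes

This account rests on a few compounds, and the source may have more. Where it says the series, first, only, none or still open, it means among the compounds named here.

Going by the values given here, in a functional assay on KB cells (Homo sapiens) for inhibition, read by MTT assay, with a stated time of 24 h, tested at 1 ug/mL (on this read-out higher numbers stand for more inhibition of growth at the one concentration tested and lower numbers for less inhibition of growth), compound 1 (`O=C(CCCCC(S)CCS)Nc1ccccc1`) gives 11.6% as the only number so far. Compound 2 (`O=C(CCCCC(S)CCS)Nc1ccccc1Cl`) is reported as "not active" (no number reported) with no number attached, and compound 3 (`O=C(CCCCC(S)CCS)Nc1cccc(Cl)c1`) is reported as "not active" (no number reported) with no number attached. Among the compounds with values here, no measured step is therefore available to size a change.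

Compound 4 (`O=C(CCCCC(S)CCS)Nc1ccc(Cl)cc1`) is still unmeasured. It differs from compound 1 by chloro in place of hydrogen on an aromatic carbon, para to a large group (chloro in place of hydrogen on an aromatic carbon).

Compound 1 at 11.6% is the only numerical anchor, so no direction is expected in this assay from the data. The estimated a number 0.6 percentage points lower from compound 1 to compound 4 (within the scatter) stays within the usual scatter. A report without a number, as for compound 2 at "not active" (no number reported) in this series, also remains possible. The estimate for compound 4 is 11% with an expected range from 0% to 25% if a number is reported.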

Compound 4, percent growth inhibition at one concentration: 13.4%
Beside the measured number, compound 4's estimate is 2.4 percentage points below it, within the range that was stated.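

In this assay, going by these compounds alone, chloro in place of hydrogen on an aromatic carbon, para to a large group, gives the first step that can be read: a number 1.8 percentage points higher from compound 1 to compound 4 (within the scatter). At this place the change therefore moves the read-out by no more than the usual scatter, and compound 4, unlike compound 2 and compound 3, which carry chloro at other places and have no number, stays on the numerical scale, while the steps to those two cannot be read. Nothing measured here offers an explanation for this result.

From the compounds shown here alone, whether another group at this same place, such as an amine or a carboxylic acid, would shift the read-out beyond the scatter remains open. Also open, going by these compounds, is whether a longer chain on the amide carbonyl side would change the picture.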